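Amide-nitrogen substituent variation in a guanidinobenzoyl-glycyl-aspartate series

The source may hold more compounds than are shown below. What is called first, only, known or untested is meant among the compounds shown, and "the series" means these compounds.

Measured so far in an assay on a protein complex for binding affinity to integrin alpha-5/beta-1 (Homo sapiens), read by ELISA, with a stated time of 1 h; on this read-out higher numbers stand for weaker inhibition and lower numbers for stronger inhibition:
compound 1 `N=C(N)Nc1cccc(C(=O)NCC(=O)N[C@@H](CC(=O)O)C(=O)Nc2ccccc2)c1` — 13 nM
compound 2 `N=C(N)Nc1cccc(C(=O)NCC(=O)N[C@@H](CC(=O)O)C(=O)NC(c2ccccc2)c2ccccc2)c1` — 22 nM
compound 3 `C[C@@H](NC(=O)[C@H](CC(=O)O)NC(=O)CNC(=O)c1cccc(NC(=N)N)c1)c1ccccc1` — 45 nM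

Compound 3 gives the highest number of the three, lying beyond the scatter from compound 2 and from compound 1. Among the measured compounds shown here, the one single-point step that reaches compound 3 is a 3.5-fold higher number from compound 1 to compound 3 (0.54 log units; beyond the scatter), a modest rise. For the measured compounds named here, compound 2 and compound 3 share no single-point step; their values simply show compound 2 with the lower number.

Compound 4 `COc1ccc(CNC(=O)[C@H](CC(=O)O)NC(=O)CNC(=O)c2cccc(NC(=N)N)c2)cc1` is the next member: 4-methoxybenzyl in place of 1-phenylethyl on an amide-type nitrogen. Going by the values given here, no measured step changes the same position in the same way, and no measured compound carries a methoxy group or a benzyl-type substituent. The measured steps only show that this position tolerates phenyl, diphenylmethyl and 1-phenylethyl within a narrow band. The expectation is therefore a step of a 1.3-fold lower number from compound 3 to compound 4 (0.11 log units; within the scatter) in this assay, not beyond the scatter. For compound 4 the estimated value in this assay is 35 nM, with a range from 12 nM to 100 nM.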

Compound 4, half-maximal inhibitory concentration: 40 nM
Estimate against measurement, compound 4: 1.1-fold (0.06 log units) below, within the range that was stated.
By their numbers in this assay, from the lowest: compounds 1, 2, 4 and 3 (each within the scatter of the next, the first and the last beyond it).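

In this assay, exchanging 1-phenylethyl for 4-methoxybenzyl on the amide-type nitrogen gives a 1.1-fold lower number from compound 3 to compound 4 (0.05 log units; within the scatter) and so does not separate the two compounds, even though the exchange removes the defined stereocentre of the substituent and adds a hydrogen-bond acceptor. Measured against the phenyl of compound 1, the new substituent gives a 3.1-fold higher number from compound 1 to compound 4 (0.49 log units; beyond the scatter) in this assay and so sits on the same side of compound 1 as 1-phenylethyl, which gives a 3.5-fold higher number from compound 1 to compound 3 (0.54 log units; beyond the scatter) as its own modest step. No available evidence bears on the reason for these values.

The compounds shown leave open what an unsubstituted benzyl or a longer chain ending in phenyl would give on this nitrogen. They also leave open whether the methoxy group contributes anything apart from the benzyl group that carries it.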